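Methoxy to amino on the pendant aryl of the shared core

A few compounds are considered here, and "the series" means these few. Any claim that something is new, unique, unknown or untested is made for them only; others in the source may bear on it.

Compound 1 `COc1ccc(-c2cc3ccccc3c(-c3cccc(OC)c3)n2)cc1` is the reference point of the series. In a functional assay on HCT-15 cells (Homo sapiens) for cytotoxicity, read by CCK-8 assay and cell counting, with a stated time of 72 h (a higher number here means a weaker inhibitor, a lower number a stronger inhibitor), compound 1 gives 1300 nM. Compound 2 `COc1ccc(-c2cc3ccccc3c(-c3cccc(N)c3)n2)cc1` carries the change amino in place of methoxy on an aromatic carbon relative to compound 1, and in this assay compound 2 gives 2350 nM. The step recorded for this pair is a 1.8-fold higher number from compound 1 to compound 2 (0.26 log units; within the scatter), so with methoxy leaving and amino entering the number moves only within the usual scatter.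

Compound 3 `COc1cc(OC)cc(-c2cc3ccccc3c(-c3cccc(OC)c3)n2)c1` has a different core from compound 1; the difference between the two cores is not broken down here. In this assay compound 3 gives 1170 nM, a number that lies within the scatter of the value of compound 1, so the two cores are not distinguished by these data.

Compound 4 `COc1cc(OC)cc(-c2cc3ccccc3c(-c3cccc(N)c3)n2)c1` has not been measured. Among the measured compounds shown here, it differs from compound 3 by amino in place of methoxy on an aromatic carbon, the same change, at a place described in the same words, as the one from compound 1 to compound 2. The expectation for compound 4 therefore rests on a single observed instance of this change, which is a narrow base, and on the close agreement of compound 1 and compound 3 in this assay. On that basis the step from compound 3 to compound 4 is expected to be a 1.8-fold higher number from compound 3 to compound 4 (0.25 log units; within the scatter), near the one measured because of a 1.8-fold higher number from compound 1 to compound 2 (0.26 log units; within the scatter). The estimate for compound 4 in this assay is 2100 nM, with a range from 1100 nM to 4200 nM expected.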

Compound 4, half-maximal inhibitory concentration: 4080 nM
For compound 4 the middle estimate is 1.9-fold (0.29 log units) below the measured one; the measured number falls inside the stated range.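

In this assay, the change from 3-methoxyphenyl to 3-aminophenyl on the core of compound 3 gives a 3.5-fold higher number from compound 3 to compound 4 (0.54 log units; beyond the scatter), whereas the same change on the core of compound 1 stays within the scatter. The two steps run in the same direction and cannot be told apart, so as far as these two pairs go, the change carries from one core to the other: the same change on two cores in this assay, a 1.8-fold higher number (0.26 log units; within the scatter) from compound 1 to compound 2 and a 3.5-fold higher number (0.54 log units; beyond the scatter) from compound 3 to compound 4, 1.9-fold (0.29 log units) apart, within the scatter of two such steps. This does not fix the size of the step or show that it would hold on any further core, and two pairs cannot settle whether the core has any influence on the step at all.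

The compounds shown leave open how a hydroxyl, a dimethylamino group or an acetamide would read at this place on either core, as only methoxy and amino appear there. Also open, from the compounds shown here alone, is whether the step would hold on a core where ethoxy groups stand in place of the methoxy groups on the other aryl ring.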